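The source may hold more compounds than are shown below. What is called first, only, known or untested is meant among the compounds shown, and "the series" means these compounds.

Compound 2 `Oc1cccc(-c2cc(-c3ccsc3)nc(-c3cccc(Cl)c3)c2)c1` is one of three close relatives sharing a common core, the others being compound 1 `Oc1cccc(-c2cc(-c3cccc(Cl)c3)nc(-c3ccco3)c2)c1` and compound 3 `Oc1cccc(-c2cc(-c3cccc(Cl)c3)nc(-c3cccs3)c2)c1`. In a functional assay on DU-145 cells (Homo sapiens) for cytotoxicity, read by CCK-8 assay and cell counting, with a stated time of 2 days (a lower number here means a stronger inhibitor, a higher number a weaker inhibitor), compound 2 gives 3330 nM, compound 1 gives 2020 nM and compound 3 gives 2650 nM. Compound 2 carries the highest of the three numbers, but the steps to it are small: a 1.6-fold higher number from compound 1 to compound 2 (0.22 log units; within the scatter), a 1.3-fold higher number from compound 1 to compound 3 (0.12 log units; within the scatter) and a 1.3-fold lower number from compound 2 to compound 3 (0.10 log units; within the scatter), all within the scatter, so the three cannot be separated.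

Compound 4 `Oc1cccc(-c2cc(-c3ccsc3)nc(-c3ccccc3Cl)c2)c1` is not yet measured. It differs from compound 2 in one place: 2-chlorophenyl in place of 3-chlorophenyl on an aromatic carbon. Among the compounds with values here, none of the measured steps touches this position; all of them exchange the five-membered ring, and each of them stays within the scatter. Within the data shown here, there is therefore no measured step that bears directly on moving the chlorine on the chlorophenyl group, and the only guidance is that single changes have so far left this assay essentially unchanged.

On that basis the step of a 1.1-fold lower number from compound 2 to compound 4 (0.05 log units; within the scatter) is expected to be small, without a clear direction. Compound 4 is estimated at 3000 nM in this assay, with a range from 1200 nM to 7500 nM.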

Compound 4, half-maximal inhibitory concentration: 1970 nM
Compound 4: the middle estimate sits 1.5-fold (0.18 log units) above what was measured, within the range that was stated.
By their numbers in this assay, from the lowest: compounds 4, 1, 3 and 2 (each within the scatter of the next).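

Within the data shown here, compound 4 provides the first measured step at the chlorophenyl group, which sits next to the ring nitrogen: in this assay, 2-chlorophenyl in place of 3-chlorophenyl gives a 1.7-fold lower number from compound 2 to compound 4 (0.23 log units; within the scatter). The earlier steps shown here exchanged only the five-membered ring, so this result extends the picture to a second position, where moving the chlorine also produces no change that can be separated from the scatter of repeated measurements. No evidence is available on what lies behind this result.

Chlorine is the only group carried on this phenyl ring in the compounds shown, so they leave open what a methoxy group, a nitrile or an amine in its place would do in this assay. The 3-hydroxyphenyl group is also the same across all four compounds, so they give no indication of how this assay would respond to a methoxy group or a carboxylic acid in place of its hydroxyl.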